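Methylamino to Aminomethyl on a Saturated Ring Carbon

A few compounds are considered here, and "the series" means these few. Any claim that something is new, unique, unknown or untested is made for them only; others in the source may bear on it.

This account follows three measured compounds and one that is yet to be measured in an assay on isolated protein for inhibition of DNA topoisomerase 1 (Homo sapiens), with a stated time of 15 min; a lower number here means a stronger inhibitor, a higher number a weaker inhibitor. Compound 1 `CN[C@@H]1CCN(c2cc3c(cc2F)c(=O)c(C(=O)O)cn3Cc2ccc(-c3ccccc3)cc2)C1` gives 34800 nM in this assay. Compound 2 `COc1c(N2CC[C@@H](CN)C2)c(F)cc2c(=O)c(C(=O)NO)cn(Cc3ccc(-c4ccccc4)cc3)c12` gives 35900 nM, and compound 3 `COc1c(N2CC[C@@H](CN)C2)c(F)cc2c(=O)c(C(=O)O)cn(Cc3ccc4ccccc4c3)c12` gives 43700 nM. Compound 1 carries the lowest of the three numbers, yet its gaps to compound 2 and to compound 3 both lie within the usual scatter of repeated measurements, so the three compounds stand together rather than in any order.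

Compound 4 `NC[C@@H]1CCN(c2cc3c(cc2F)c(=O)c(C(=O)O)cn3Cc2ccc(-c3ccccc3)cc2)C1` has not yet been measured in this assay. It differs from compound 1 in one place: aminomethyl in place of methylamino on a saturated ring carbon. The two compounds have the same atoms, joined differently.

Going by the values given here, no step between measured compounds is available here, so the expectation rests on the standing of the three numbers alone. The values of compound 2 and compound 3 sit with the value of compound 1 within the scatter, and the rearrangement is small. The expected step is a 1.1-fold higher number from compound 1 to compound 4 (0.04 log units; within the scatter), which is to say none beyond the scatter. The estimate for compound 4 in this assay is 38000 nM, with a range from 15000 nM to 95000 nM.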

Compound 4, half-maximal inhibitory concentration: 15600 nM
Estimate against measurement, compound 4: 2.4-fold (0.39 log units) above; the measured number falls inside the stated range.
By their numbers in this assay, from the lowest: compound 4; then compounds 1, 2 and 3 (each within the scatter of the next).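

In this assay the exchange of methylamino for aminomethyl on a saturated ring carbon of the five-membered ring gives a 2.2-fold lower number from compound 1 to compound 4 (0.35 log units; beyond the scatter) and this modest step lies beyond the scatter. The earlier compounds shown here could not show this, since they stood together within the scatter and no two of them differed in one place only; this pair shows that the same atoms, joined differently and with the same counts of hydrogen-bond donors and acceptors, are enough to separate two numbers at this position. No measurement among those shown accounts for the step.

Going by these compounds, it remains open whether a plain amino group or a dimethylamino group on the same ring carbon would stand with compound 1 or with compound 4, and whether a longer chain such as aminoethyl would extend the step or reverse it. On these data alone, it is also open whether the step holds on other cores: compound 2 and compound 3 carry aminomethyl as well, but each differs from compound 4 in more than one place, so neither can test it.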